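The compounds below may be only part of what the source reports. "The series", "measured", "known", "first", "only" and "open" are said of these compounds alone.

Of the compounds shown here, three built on a shared core have been measured in an in vitro assay on BHK cells for binding affinity to gastric inhibitory polypeptide receptor (Homo sapiens); a lower number here means a stronger inhibitor, a higher number a weaker inhibitor. Compound 1 `O=C(O)CCNC(=O)c1ccc(CN(C(=O)Nc2cc(Cl)cc(Cl)c2)c2ccc(C3=CCCCC3)cc2)cc1` gives 64 nM. Compound 2 `O=C(NC[C@@H](O)C(=O)O)c1ccc(CN(C(=O)Nc2cccc(Br)c2)c2ccc(C3CCCCC3)cc2)cc1` gives 216 nM, and compound 3 `COc1cc(NC(=O)N(Cc2ccc(C(=O)NC[C@@H](O)C(=O)O)cc2)c2ccc(C3=CCCCC3)cc2)cc(C(F)(F)F)c1` gives 279 nM. Among these three numbers compound 2 stands second highest; the number for compound 3 sits closest to it, and the two lie within the scatter of repeated measurements, so no order between them can be read. The number for compound 1 is the furthest from that of compound 2 and lies beyond the scatter, so compound 1 is the stronger inhibitor of that pair.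

Compound 4 `O=C(NC[C@@H](O)C(=O)O)c1ccc(CN(C(=O)Nc2cc(Cl)cc(Cl)c2)c2ccc(C3CCCCC3)cc2)cc1` has not yet been measured in this assay. It differs from compound 2 in one place: 3,5-dichlorophenyl in place of 3-bromophenyl on an amide-type nitrogen. Among the compounds with values here, no pair of measured compounds differs in this place alone, so no directly comparable step is known. Within the data shown here, compound 1, the one measured compound carrying the 3,5-dichlorophenyl group, gives 64 nM, yet it differs from compound 2 elsewhere too, so that number cannot be assigned to this change alone. A step of modest size towards a lower number, a 1.8-fold lower number from compound 2 to compound 4 (0.26 log units; within the scatter), is what is expected here. Compound 4 is estimated to give 120 nM, within a range from 45 nM to 320 nM.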

Compound 4, half-maximal inhibitory concentration: 93 nM
Beside the measured number, compound 4's estimate is 1.3-fold (0.11 log units) above it; low and high end bracket the measured number.
By their numbers in this assay, from the lowest: compounds 1 and 4 (each within the scatter of the next); then compounds 2 and 3 (each within the scatter of the next).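

The pair gives the first step read at this position. In this assay, with everything else in the molecule held the same, putting 3,5-dichlorophenyl in place of 3-bromophenyl on the amide-type nitrogen gives a 2.3-fold lower number from compound 2 to compound 4 (0.37 log units; beyond the scatter), so the aryl group at this place bears on the number on its own, which compound 1 could not show since it differs from compound 2 elsewhere too. Nothing at hand gives a measured property or other finding that would explain this step, so the result stands as an observation for this single pair.

The change also joins two differences in one step, the loss of a bromine and the arrival of two chlorines, and a 3-chlorophenyl or a 3,5-dibromophenyl group on the same nitrogen would be needed to tell them apart. Going by these compounds, whether the same change gives a step of like size when the rest of the molecule differs, as it does in compound 1, also remains open.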